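The source may hold more compounds than are shown below. What is called first, only, known or untested is meant among the compounds shown, and "the series" means these compounds.

Working notes on the series of the shared core carrying a hydroxymethyl-bearing ring, tested in an ADME assay on L02 cells (Homo sapiens) for cytotoxicity, read by MTT assay, with a stated time of 48 h; on this read-out higher numbers stand for weaker inhibition and lower numbers for stronger inhibition.

Compound 1 `O=C1O[C@@H](CO)CN1c1ccc(-n2cc(-c3ccccn3)cn2)c(F)c1` carries hydrogen on the oxygen on a saturated carbon and gives 59 ug/mL in this assay. Compound 2 `O=C1O[C@@H](CN2CCC(c3ccc(F)cc3)CC2)CN1c1ccc(-n2cc(-c3ccccn3)cn2)c(F)c1` reaches only a limit of the assay in this assay, reported as > 400 ug/mL. Compound 3 `O=C(OC[C@H]1CN(c2ccc(-n3cc(-c4ccccn4)cn3)c(F)c2)C(=O)O1)c1ccccc1` likewise reaches only a limit in this assay, reported as > 400 ug/mL. Compound 3 thus stands at the limit of > 400 ug/mL in this assay, at which 2 of the 3 values shown sit, so only a bound and no number is known for it. Within the data shown here, the one step recorded in this assay, an at least 6.7-fold higher number from compound 1 to compound 3 (0.83 log units; beyond the scatter), moved the number from a measured value to that limit.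

Compound 4 `CCNC(=O)NC[C@H]1CN(c2ccc(-n3cc(-c4ccccn4)cn3)c(F)c2)C(=O)O1` differs from compound 3 in one place, ((ethylcarbamoyl)amino in place of benzoyloxy on a saturated chain carbon bound to a saturated ring carbon). Among the measured compounds shown here, the only measured step that bears on the change at this oxygen-bearing chain carbon is the one from compound 1 to compound 3, which was at least modest and upward; no step connects compound 2 to either. Both substituted analogues, compound 2 and compound 3, sit at the limit, while only compound 1 with hydrogen there gives a number. Compound 4 is therefore expected to lie near the upper end of the measured range, with the step of an at least 1.3-fold lower number from compound 3 to compound 4 (0.12 log units; that floor lies within the scatter) expected to be small or not resolvable against a limit. The estimate for compound 4 in this assay is 300 ug/mL, within 100 ug/mL to 400 ug/mL, with a fair chance that only a limit is reported.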

Compound 4, half-maximal inhibitory concentration: > 400 ug/mL
Compound 4 was reported as a limit; the forecaster's own chance of this, stated with the estimate: 55%; at least 1.3-fold (0.12 log units) between middle value and limit.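

In this assay, (ethylcarbamoyl)amino in place of hydroxy on a saturated chain carbon bound to a saturated ring carbon gives an at least 6.7-fold higher number from compound 1 to compound 4 (0.83 log units; beyond the scatter), a shift of the same reading as an at least 6.7-fold higher number from compound 1 to compound 3 (0.83 log units; beyond the scatter), even though benzoyloxy has an aromatic ring and no hydrogen-bond donors while (ethylcarbamoyl)amino has no ring and does have hydrogen-bond donors. The high reading at this place is therefore no longer tied to benzoyloxy alone, although the step between compound 3 and compound 4 cannot be read, since both ends are limits. Compound 2, compound 3 and compound 4 all end at the same limit, leaving compound 1, with hydroxy, as the only compound here with a measured number: the limit of > 400 ug/mL in this assay, at which 3 of the 4 values shown sit.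

On these data alone, how far the true values of compound 2, compound 3 and compound 4 lie from one another stays unknown, so the groups at this place cannot be ranked. As far as these compounds go, whether a primary amine, a carboxylic acid or a methyl ether on this chain carbon would give a measured number rather than a limit remains open.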